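The compounds below may be only part of what the source reports. "The series", "measured", "known", "first", "only" and "open" are said of these compounds alone.

Compound 2, `O=C(Nc1cccc(-c2cnco2)c1)C1CCCN(C(=O)c2cc(C(F)(F)F)cc(C(F)(F)F)c2)C1`, is the starting point of this step. In an ADME assay on PC-3 cells (Homo sapiens) for cytotoxicity, read by WST assay, tested at 100 uM (a higher number here means more inhibition at the concentration tested (going by the name of the read-out), a lower number less inhibition), compound 2 gives 9%. For the measured compounds named here, the only other measured compound is compound 1, `CC(=O)c1cccc(NC(=O)C2CCCN(C(=O)c3cc(C(F)(F)F)cc(C(F)(F)F)c3)C2)c1`, which in this assay gives 0%. The two numbers sit within the usual scatter of each other, so compound 2 cannot be set apart from compound 1 on these results: both show essentially no inhibition at the concentration tested.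

The step to compound 3, `O=C(Nc1ccc(Cl)cn1)C1CCCN(C(=O)c2cc(C(F)(F)F)cc(C(F)(F)F)c2)C1`, is 5-chloropyridin-2-yl in place of 3-(1,3-oxazol-5-yl)phenyl on an amide-type nitrogen. Going by the values given here, the only measured step, a number 9 percentage points higher from compound 1 to compound 2 (within the scatter), changed a group on an aromatic carbon of the amide-bearing ring and did not move the read-out beyond the scatter; it concerns a different part of the molecule than the present change, so it gives only indirect guidance. With both measured compounds near zero and no step beyond the scatter, the expectation for compound 3 in this assay is a step of a number 4 percentage points lower from compound 2 to compound 3 (within the scatter), that is, no change beyond the scatter. Compound 3 is therefore estimated at 5%, within a range from -10% to 25%.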

Compound 3, a percentage reported as inhibition, at one concentration (the size of the read-out at that concentration, not a potency): 0%
For compound 3 the middle estimate is 5 percentage points above the measured one; the measured number falls inside the stated range.
By their numbers in this assay, from the lowest: compounds 1, 3 and 2 (each within the scatter of the next).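

In this assay, replacing 3-(1,3-oxazol-5-yl)phenyl with 5-chloropyridin-2-yl on the amide-type nitrogen gives a number 9 percentage points lower from compound 2 to compound 3 (within the scatter) and replacing 3-acetylphenyl with the same group gives no change at the digits printed from compound 1 to compound 3 (within the scatter) as the printed result. The earlier step altered only a group carried on the aromatic ring, whereas these two steps exchange the whole aromatic group on the amide-type nitrogen, bringing in a ring nitrogen and a chlorine. Even this larger change of structure leaves all three compounds indistinguishable in this read-out, so the position has so far produced no difference beyond the scatter, in either the phenyl or the pyridinyl series. No supporting measurement is available that would explain this result.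

On these data alone, whether an amine or a carboxylic acid on the ring at the amide-type nitrogen, or a longer alkyl chain in place of that ring, would give a number beyond the scatter remains open. The rest of the shared core is the same in all three compounds, so what a change there would do in this assay is also unanswered.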